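The source may report more compounds than this note shows. Statements on the series, on what has been measured and on what is new or still open speak of the compounds shown alone.

Among the measured compounds shown here, in an assay on cells for inhibition of histone-lysine N-methyltransferase EZH2 (Homo sapiens), read by ELISA, with a stated time of 72 h (on this read-out lower numbers stand for stronger inhibition and higher numbers for weaker inhibition), compound 2 `Cc1cc(C)c(CN2CCc3c(Cl)cc([C@H](CO)[C@H]4CCCO4)c(Cl)c3C2=O)c(=O)[nH]1` gives 40 nM, the only number reported for it; two further readings yielded no single figure. Compound 1 `COC(c1cc(Cl)c2c(c1Cl)C(=O)N(Cc1c(C)cc(C)[nH]c1=O)CC2)C1CCOCC1` in this assay gives 1460 nM; 9 nM (2 entries), and compound 3 `COC(c1cc(Cl)c2c(c1Cl)C(=O)N(Cc1c(C)cc(C)[nH]c1=O)CC2)C1CCN(C2COC2)CC1` gives 1310 nM; 16 nM (2 entries); both spreads lie far outside the usual scatter. Compound 4 `Cc1cc(C)c(CN2CCc3c(Cl)cc([C@@H](CO)[C@H]4CCCO4)c(Cl)c3C2=O)c(=O)[nH]1` differs from compound 2 only in configuration: the two compounds have the same atoms and bonds and differ only in configuration as drawn: 1 of 2 stereo elements differ; a stereocentre at a saturated chain carbon is drawn R in compound 2 and S in compound 4. For the measured compounds named here, no measured pair here isolates this change, so its size is uncertain. Because the several entries of compound 1 in this assay, 1460 nM; 9 nM (2 entries) and the several entries of compound 3 in this assay, 1310 nM; 16 nM (2 entries) show repeat readings of one drawn structure landing far apart, a large step is plausible. Compound 4 is therefore expected to be weaker, with the step of a 10-fold higher number from compound 2 to compound 4 (1.00 log units; beyond the scatter) reaching beyond the scatter. Compound 4 is estimated at 400 nM, within 30 nM to 4000 nM.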

Compound 4, half-maximal inhibitory concentration: 1020 nM
Beside the measured number, compound 4's estimate is 2.6-fold (0.41 log units) below it; the measured number falls inside the stated range.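

Among the compounds shown here, compounds 2 and 4 form the first measured pair here that isolates a single stereocentre: the fact that compounds 2 and 4 differ only in the configuration as drawn. In this assay, switching that saturated chain carbon from R to S gives a 26-fold higher number from compound 2 to compound 4 (1.41 log units; beyond the scatter), so configuration alone can shift the number well beyond the usual scatter. The exact size remains uncertain, as repeat readings of one structure can land far apart: the several entries of compound 1 in this assay, 1460 nM; 9 nM (2 entries)

Still open, from the compounds shown here alone, is how the other stereo element, drawn alike in compounds 2 and 4, affects inhibition. Also open, going by these compounds, is whether this configuration matters equally with an amine or a carboxylic acid in place of the alcohol.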